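From a Chlorophenyl Ketone to a Pyridinyl Ketone

The source may hold more compounds than are shown below. What is called first, only, known or untested is meant among the compounds shown, and "the series" means these compounds.

Of the compounds shown here, two have so far been measured in an assay on cells (1-87 tumor cell line) for inhibition of Polyunsaturated fatty acid 5-lipoxygenase (Homo sapiens), with a stated time of 5 min; on this read-out lower numbers stand for stronger inhibition and higher numbers for weaker inhibition. Compound 1 `COc1ccc(C(=O)CC2CC(=O)N(c3ccc(S(N)(=O)=O)cc3)C2=O)cc1` gives 4740 nM. Among the compounds with values here, compound 2 `NS(=O)(=O)c1ccc(N2C(=O)CC(CC(=O)c3ccc(Cl)cc3)C2=O)cc1` gives 12600 nM, the higher of the two numbers; the only measured step, a 2.7-fold higher number from compound 1 to compound 2 (0.42 log units; beyond the scatter), separates them. Compound 3 `NS(=O)(=O)c1ccc(N2C(=O)CC(CC(=O)c3ccccn3)C2=O)cc1` is the next compound to be measured. It differs from compound 2 in one place: pyridin-2-yl in place of 4-chlorophenyl on a carbonyl carbon. The measured step bears on this only loosely, since it also altered the aromatic ring attached to the carbonyl, and a 2.7-fold higher number from compound 1 to compound 2 (0.42 log units; beyond the scatter) shows that such a change can shift the number by a modest amount. Nothing measured shows what a pyridin-2-yl ring does here, so the direction is open. For compound 3 a modest change is expected, with an estimated value of 9000 nM and a range from 3000 nM to 27000 nM. This expected step corresponds to a 1.4-fold lower number from compound 2 to compound 3 (0.15 log units; within the scatter).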

Compound 3, half-maximal inhibitory concentration: 810 nM
For compound 3 the middle estimate is 11-fold (1.05 log units) above the measured one; measured number outside the range, below it.
By their numbers in this assay, from the lowest: compound 3; then compound 1; then compound 2.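

Changing the aromatic ring on this carbonyl carbon can move the number much further than the earlier step showed: in this assay, pyridin-2-yl in place of 4-chlorophenyl gives a 16-fold lower number from compound 2 to compound 3 (1.19 log units; beyond the scatter) as a large step. Pyridin-2-yl also compares well with the 4-methoxyphenyl ring (a 5.9-fold lower number from compound 1 to compound 3 (0.77 log units; beyond the scatter)), so compound 3 has the lowest number of the three, and both of its steps lie beyond the scatter. Nothing available explains this gain. The compounds shown leave open whether the ring nitrogen matters, as the step also removes the chlorine, and a plain phenyl ring would help to separate those two changes. They also leave open whether the position of the nitrogen counts, a question that pyridin-3-yl or pyridin-4-yl could address.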